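Phenyl in Place of the Nitrile Chain

This account rests on a few compounds, and the source may have more. Where it says the series, first, only, none or still open, it means among the compounds named here.

compound 1, `CN1C(=S)[C@@H](NC(=O)c2nc(Cc3ccccc3)n(CCCC#N)n2)COc2ccccc21`: 2400 nM
compound 2, `CN1C(=S)[C@@H](NC(=O)c2nc(Cc3ccccc3)n(CCCCC#N)n2)COc2ccccc21`: 2680 nM
compound 3, `CN1C(=S)[C@@H](NC(=O)c2nc(Cc3ccccc3)n(CCCCCC#N)n2)COc2ccccc21`: 3830 nM

The three measured compounds share one core and differ only in the length of the nitrile-bearing chain on the aromatic nitrogen. In a functional assay on HT-29 cells (Homo sapiens) for inhibition, read by luminescence and CellTiter-Glo, with a stated time of 24 h (on this read-out higher numbers stand for an effect only at larger amounts of compound and lower numbers for an effect already at smaller amounts), compound 1 has the lowest number of the three, but this standing carries little weight: its steps to the other two, a 1.1-fold higher number from compound 1 to compound 2 (0.05 log units; within the scatter) and a 1.6-fold higher number from compound 1 to compound 3 (0.20 log units; within the scatter), both stay within the scatter, as does a 1.4-fold higher number from compound 2 to compound 3 (0.16 log units; within the scatter). The three values cannot be separated.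

Compound 4, `CN1C(=S)[C@@H](NC(=O)c2nc(Cc3ccccc3)n(Cc3ccccc3)n2)COc2ccccc21`, has not been measured. It differs from compound 1 in a single place: phenyl in place of 2-cyanoethyl on a saturated chain carbon bound to an aromatic nitrogen. The measured steps all concern lengthening the nitrile chain; none exchanges it for a ring. They bear on the new change only in showing that this position accepts alteration without a step beyond the scatter. On that basis the step of a 1.0-fold higher number from compound 1 to compound 4 (0.02 log units; within the scatter) is expected to be modest and of no firm direction, though a ring in place of a chain warrants a wider range than a chain-length change would. Compound 4 is estimated at 2500 nM, with a range from 800 nM to 8000 nM.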

Compound 4, half-maximal effective concentration: 414 nM
For compound 4 the middle estimate is 6.0-fold (0.78 log units) above the measured one, and the stated range ends above it.
By their numbers in this assay, from the lowest: compound 4; then compounds 1, 2 and 3 (each within the scatter of the next).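

In this assay the place on a saturated chain carbon bound to an aromatic nitrogen had shown no step beyond the scatter while only the length of the nitrile chain varied, yet the exchange of 3-cyanopropyl for benzyl gives a 5.8-fold lower number from compound 1 to compound 4 (0.76 log units; beyond the scatter) and so separates compound 4 clearly from the chain series. Compound 4 also stands clear of both longer chains, with a 6.5-fold lower number from compound 2 to compound 4 (0.81 log units; beyond the scatter) and with a 9.3-fold lower number from compound 3 to compound 4 (0.97 log units; beyond the scatter) as well, so the number at this place depends on more than chain length. The change removes the nitrile and its hydrogen-bond acceptor and brings in a six-membered aromatic ring of carbon only in one step, and nothing at hand accounts for the lower number.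

As far as these compounds go, it remains open whether the entering ring or the departing nitrile carries the step, a question that a plain butyl chain or a benzyl group bearing a nitrile on its ring could address. Equally open, from the compounds shown here alone, is how a longer 2-phenylethyl group or a pyridylmethyl group would read at this place.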